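A fluorophenoxy swap tested on melanoma cells

The source may hold more compounds than are shown below. What is called first, only, known or untested is meant among the compounds shown, and "the series" means these compounds.

Compound 1 `Nc1cc(N)c2nc(-c3ccccc3)c(Oc3ccc(Cl)c(Cl)c3)nc2c1` gives < 100000 nM in a functional assay on M14 cells (Homo sapiens) for inhibition, read by sulforhodamine B assay, with a stated time of 48 h (a lower number here means that less compound is tolerated, a higher number that more compound is tolerated), which is a limit rather than a number.
Compound 2 `COc1ccc(CNc2nc3cc(N)cc(N)c3nc2-c2ccccc2)cc1` gives 57500 nM in this assay.

On these data alone, compound 1 thus stands only at a limit in this assay, as the limit of < 100000 nM in this assay, at which 1 of the 2 values shown sits, shows, so its exact value is unknown. Compound 3 `Nc1cc(N)c2nc(-c3ccccc3)c(Oc3ccc(F)cc3)nc2c1` is the unmeasured partner, carrying (4-fluorophenyl in place of 3,4-dichlorophenyl on an oxygen on an aromatic ring). Among the compounds with values here, no measured pair shares this change, so the expected step is small. Compound 3 is expected to shift from compound 1 by a step that the limit leaves unreadable from compound 1 to compound 3 in this assay, within the usual scatter. Compound 3 is estimated at 60000 nM in this assay, with a range from 20000 nM to 100000 nM.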

Compound 3, concentration lethal to 50% of the cells: < 100000 nM
Compound 3: no number, only a limit; the forecaster's own chance of this, stated with the estimate: 40%; the middle value does not contradict the limit.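

In this assay, within the data shown here, compound 1 and compound 3 each give only a limit, so no step between them can be read. Where each truly stands, and whether swapping 3,4-dichlorophenyl for 4-fluorophenyl changes anything, remains open.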